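A Thiazole Acid Replaces the Phenylpropanoic Acid

The source may hold more compounds than are shown below. What is called first, only, known or untested is meant among the compounds shown, and "the series" means these compounds.

Compound 2 `O=C(O)CCc1ccc(NC(=O)C(C2CCCCC2)n2c(-c3ccc(Cl)cc3)nc3cc(F)c(F)cc32)cc1` holds the lowest number of the two measured compounds: in an assay on isolated protein for displacement of a labelled ligand from Bile acid receptor (Homo sapiens), read by scintillation proximity assay and radioligand binding (on this read-out lower numbers stand for stronger inhibition and higher numbers for weaker inhibition), compound 2 gives 60 nM, while compound 1 `O=C(O)c1ccccc1NC(=O)C(C1CCCCC1)n1c(-c2ccc(Cl)cc2)nc2cc(F)c(F)cc21` gives 320 nM. Compound 3 `Cc1nc(NC(=O)C(C2CCCCC2)n2c(-c3ccc(Cl)cc3)nc3cc(F)c(F)cc32)sc1C(=O)O` carries 5-carboxy-4-methyl-1,3-thiazol-2-yl in place of 4-(2-carboxyethyl)phenyl on an amide-type nitrogen. For the measured compounds named here, only one measured step bears on this change, a 5.3-fold lower number from compound 1 to compound 2 (0.73 log units; beyond the scatter), and it shows that the shape of the acid-bearing group matters here. Since the thiazole acid of compound 3 matches neither earlier arrangement closely, a modest rise in its number is expected, a 2.5-fold higher number from compound 2 to compound 3 (0.40 log units; beyond the scatter). Compound 3 is therefore estimated at 150 nM, with a range from 40 nM to 600 nM.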

Compound 3, half-maximal inhibitory concentration: 90 nM
Beside the measured number, compound 3's estimate is 1.7-fold (0.22 log units) above it; the range from low to high includes it.
By their numbers in this assay, from the lowest: compounds 2 and 3 (each within the scatter of the next); then compound 1.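

The amide-type nitrogen accepts 5-carboxy-4-methyl-1,3-thiazol-2-yl as well as 4-(2-carboxyethyl)phenyl: in this assay this exchange gives a 1.5-fold higher number from compound 2 to compound 3 (0.18 log units; within the scatter), so the two groups cannot be told apart. Measured against 2-carboxyphenyl, the same thiazole group gives a 3.6-fold lower number from compound 1 to compound 3 (0.55 log units; beyond the scatter), so the gain over compound 1 does not belong to 4-(2-carboxyethyl)phenyl alone. Nothing available explains why these different acid-bearing groups read alike.

Still open, going by these compounds, is whether a primary amide or a tetrazole could stand in for the carboxylic acid on the thiazole, and whether the methyl group there contributes to the result.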